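Swapping a Thiazole for a Furan on the Shared Core

The source may hold more compounds than are shown below. What is called first, only, known or untested is meant among the compounds shown, and "the series" means these compounds.

Compound 1 `O=C(/C=C/c1nccs1)c1cc(O)c(O)c([N+](=O)[O-])c1` was tested in an assay on isolated protein for inhibition of Amine oxidase [flavin-containing] B (Homo sapiens), read by fluorescence (on this read-out higher numbers stand for weaker inhibition and lower numbers for stronger inhibition), where compound 1 gives 59200 nM. Compound 2 `N#Cc1cccc(/C=C/C(=O)c2cc(O)c(O)c([N+](=O)[O-])c2)c1` gives 60600 nM in this assay; the two values lie within the scatter of each other, so compound 1 merely holds the lower of the two numbers. Compound 3 `O=C(/C=C/c1ccco1)c1cc(O)c(O)c([N+](=O)[O-])c1` differs from compound 1 by furan-2-yl in place of 1,3-thiazol-2-yl on a double-bonded chain carbon bound to a double-bonded chain carbon. Among the compounds with values here, no measured pair shows this change, so the move from compound 1 to compound 3 is expected to stay within the scatter, with no clear direction. Compound 3 is estimated at 55000 nM, with a range from 25000 nM to 120000 nM. The expected step of a 1.1-fold lower number from compound 1 to compound 3 (0.03 log units; within the scatter) is small.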

Compound 3, half-maximal inhibitory concentration: 68200 nM
Beside the measured number, compound 3's estimate is 1.2-fold (0.09 log units) below it; the range from low to high includes it.
By their numbers in this assay, from the lowest: compounds 1, 2 and 3 (each within the scatter of the next).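

At this place, on a double-bonded chain carbon bound to a double-bonded chain carbon, furan-2-yl in place of 1,3-thiazol-2-yl gives a 1.2-fold higher number from compound 1 to compound 3 (0.06 log units; within the scatter) in this assay. This single measured exchange shows that moving between these two five-membered aromatic rings, with 1 hetero atom rather than 2, does not separate the compounds. No evidence is available that bears on this result. Still open, going by these compounds, is whether an amine or a carboxylic acid at this place would shift the number beyond the scatter.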